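Adding a chloro to the acetylsulfonamide pyrazole

A few compounds are considered here, and "the series" means these few. Any claim that something is new, unique, unknown or untested is made for them only; others in the source may bear on it.

Two compounds share a core carrying a dimethoxyphenyl group on a pyrazole. Compound 1 `COc1ccc(OC)c(-c2cc(-c3ccc(Cl)cc3)nn2-c2ccccc2)c1` bears a chlorophenyl on the pyrazole and a plain phenyl on the ring nitrogen; in a functional assay on cells (Cancer cell lines, Homo sapiens) for cytotoxicity, read by sulforhodamine B assay, with a stated time of 48 h (on this read-out lower numbers stand for stronger inhibition of growth and higher numbers for weaker inhibition of growth), compound 1 gives 82800 nM. Compound 2 `COc1ccc(OC)c(-c2cc(-c3ccccc3)nn2-c2ccc(S(=O)(=O)NC(C)=O)cc2)c1` instead carries an unsubstituted phenyl on the pyrazole and an acetylsulfonamide-bearing phenyl on the nitrogen; in this assay compound 2 gives 18200 nM, the lower of the two numbers, and the gap to compound 1 lies beyond the usual scatter. The two compounds differ in more than one place, so the data show only their two values.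

Compound 3 `COc1ccc(OC)c(-c2cc(-c3ccc(Cl)cc3)nn2-c2ccc(S(=O)(=O)NC(C)=O)cc2)c1` is not yet measured. It arises from compound 2 by a single change: chloro in place of hydrogen on an aromatic carbon. Within the data shown here, no measured pair isolates this change, so in this assay the step from compound 2 to compound 3 is expected to stay within the scatter, a 1.2-fold lower number from compound 2 to compound 3 (0.08 log units; within the scatter) in either direction. Compound 3 is therefore estimated at 15000 nM, within a range of 6000 nM to 40000 nM.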

Compound 3, concentration for total growth inhibition: 36000 nM
For compound 3 the middle estimate is 2.4-fold (0.38 log units) below the measured one, and the stated range covers the measured number.
By their numbers in this assay, from the lowest: compounds 2 and 3 (each within the scatter of the next); then compound 1.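

Among these compounds, with compound 3, the change from phenyl to 4-chlorophenyl can be read on its own for the first time: in this assay the step is a 2.0-fold higher number from compound 2 to compound 3 (0.30 log units; within the scatter), so with the acetylsulfamoyl group in place, this chloro has no effect that can be told from the scatter. Compound 3 also isolates the acetylsulfamoyl group, which the earlier pair could not do: with the 4-chlorophenyl kept, the step is a 2.3-fold lower number from compound 1 to compound 3 (0.36 log units; beyond the scatter), a modest change that lies beyond the scatter. Nothing available explains either step.

The compounds shown leave open whether a methoxy or an amine at the chloro position would move the number beyond the scatter. They also leave open how a carboxylic acid in place of the acetylsulfamoyl group would compare.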